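The compounds below may be only part of what the source reports. "The series", "measured", "known", "first", "only" and "open" are said of these compounds alone.

Of the compounds shown here, three sharing one core have been tested in an ADME assay on Huh7.5.1 cells (Homo sapiens) for cytotoxicity, read by WST assay, with a stated time of 48 h; a lower number here means that less compound is tolerated, a higher number that more compound is tolerated: compound 1 `Cc1c(-c2ccc(Cc3ccc(S(=O)(=O)C(F)(F)F)cc3)cc2)[nH]c2cccc(F)c2c1=O`, compound 2 `Cc1c(-c2ccc(Cc3ccc(S(=N)(=O)C(F)(F)F)cc3)cc2)[nH]c2cccc(F)c2c1=O` and compound 3 `Cc1c(-c2ccc(Cc3ccc(S(F)(F)(F)(F)F)cc3)cc2)[nH]c2cccc(F)c2c1=O`. Compound 1 gives > 2500 nM, which is a limit and not a number. Compound 2 gives > 10000 nM, which is also a limit. Compound 3 gives > 5000 nM, again a limit, so it has no measured number to stand on, and neither do the other two compounds.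

Compound 4 `Cc1c(-c2ccc(Cc3ccc(Cl)cc3)cc2)[nH]c2cccc(F)c2c1=O` has not yet been measured. It carries this change from compound 3: one chlorine atom in place of a group of 6 heavy atoms (5 fluorine, 1 sulfur; no ring), on an aromatic carbon. The measured steps all fall on that same aromatic carbon: a step that the two limits leave unreadable from compound 1 to compound 2, a step that the two limits leave unreadable from compound 1 to compound 3 and a step that the two limits leave unreadable from compound 2 to compound 3. None of the three involves the chloro group, and none has a size that could be carried over.

Since a step that the two limits leave unreadable from compound 2 to compound 3 offers no readable size, and the same holds for a step that the two limits leave unreadable from compound 1 to compound 3, no shift beyond the usual scatter is expected in this assay, in either direction. The expected change is a step that the limit leaves unreadable from compound 3 to compound 4. The result may well be reported as a limit once more. Compound 4 is estimated at 8000 nM, with an expected range from 2500 nM to 25000 nM.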

Compound 4, half-maximal cytotoxic concentration: > 10000 nM
Compound 4 ended at the assay's limit; the forecaster's own chance of this, stated with the estimate: 70%; middle value at least 1.2-fold (0.09 log units) away from the limit.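

In this assay compound 4 gives > 10000 nM, which is a limit and not a number. No new step can be read, as the steps to compound 4 from compound 1, compound 2 and compound 3 all join two limits. The compounds shown leave open how the chloro group and the three sulfur-containing groups truly compare on this aromatic carbon.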